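Thiophen-3-yl for phenyl on a pyridine-type core

The compounds below may be only part of what the source reports. "The series", "measured", "known", "first", "only" and "open" are said of these compounds alone.

Measured compounds:
compound 2, `Oc1cccc(-c2cc(-c3ccc(Cl)cc3)nc(-c3ccsc3)c2)c1`: 11600 nM
compound 3, `Oc1cccc(-c2cc(-c3ccccc3)nc(-c3ccccc3Cl)c2)c1`: 1480 nM
compound 1, `Oc1cccc(-c2cc(-c3cccnc3)nc(-c3ccccc3Cl)c2)c1`: "not determined" (no result reported)

Compound 3 sits at the low end of the two numbers in a functional assay on DU-145 cells (Homo sapiens) for cytotoxicity, read by CCK-8 assay and cell counting, with a stated time of 2 days (a lower number here means a stronger inhibitor, a higher number a weaker inhibitor), where compound 3 gives 1480 nM. The nearest neighbour is compound 2, which in this assay gives 11600 nM, a gap that lies beyond the scatter. Compound 1 in this assay gives "not determined" (no result reported), so it adds no number to the comparison.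

Compound 4, `Oc1cccc(-c2cc(-c3ccsc3)nc(-c3ccccc3Cl)c2)c1`, differs from compound 3 in one place: thiophen-3-yl in place of phenyl on an aromatic carbon, the thiophen-3-yl entering next to the ring nitrogen, meta to the 2-chlorophenyl group and meta to the 3-hydroxyphenyl group. Going by the values given here, no pair of measured compounds shows this change alone, so its size cannot be read from the data. Compound 2 carries a thiophen-3-yl at the same place but a 4-chlorophenyl elsewhere. Among the compounds with values here, compound 2 and compound 3 therefore differ in more than one place, and their two values show only that compound 2 gives the higher number.

The step from compound 3 to compound 4 is expected to be modest and toward a weaker inhibitor, a 1.7-fold higher number from compound 3 to compound 4 (0.23 log units; within the scatter). Compound 4 is estimated at 2500 nM, within a range from 800 nM to 8000 nM.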

Compound 4, half-maximal inhibitory concentration: 1970 nM
Beside the measured number, compound 4's estimate is 1.3-fold (0.10 log units) above it; measured number inside the range.
By their numbers in this assay, from the lowest: compounds 3 and 4 (each within the scatter of the next); then compound 2.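

With this assay as the read-out, the exchange at this position can now be read on its own: thiophen-3-yl in place of phenyl, on the aromatic carbon next to the ring nitrogen, gives a 1.3-fold higher number from compound 3 to compound 4 (0.12 log units; within the scatter) and so leaves no change that stands clear of the scatter. Compound 4 also links the series through a second single change, with thiophen-3-yl held in place and 2-chlorophenyl in place of 4-chlorophenyl, which gives a 5.9-fold lower number from compound 2 to compound 4 (0.77 log units; beyond the scatter); of the two single changes, only this one lies beyond the scatter, so the swap of the five-membered sulfur ring for phenyl is not the step that carries a clear difference here. No measurement accompanies these numbers that would explain either step.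

What these compounds leave open is whether the same holds for other groups at this position, such as a furan-3-yl ring, a cyclohexyl ring or an aminomethyl group, since only phenyl and thiophen-3-yl can be compared there. On these data alone, it is also open whether the 3-hydroxyphenyl group could give way to a 3-methoxyphenyl or a 3-carboxyphenyl group without a step beyond the scatter.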